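Swapping a naphthalene for a methylphenyl on the sulfur linker

The source may hold more compounds than are shown below. What is called first, only, known or untested is meant among the compounds shown, and "the series" means these compounds.

Of the compounds shown here, two of a shared core have been tested in an ADME assay on HaCaT cells (Homo sapiens) for cytotoxicity, read by MTT assay, with a stated time of 72 h; a lower number here means a stronger inhibitor, a higher number a weaker inhibitor. Compound 1, `Cc1cccc(CSc2cc(Cl)c(C)cc2S(=O)(=O)/N=C(\N)n2nccc2-c2ccccc2)c1`, gives 10000 nM in this assay. Compound 2, `Cc1cc(-c2ccccc2)n(/C(N)=N/S(=O)(=O)c2cc(C)c(Cl)cc2SCc2cccc3ccccc23)n1`, gives 12000 nM in this assay. Compound 2 holds the higher of the two numbers, but the gap to compound 1 lies within the scatter of repeated measurements, so the two results cannot be told apart.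

Compound 3, `Cc1ccc(CSc2cc(Cl)c(C)cc2S(=O)(=O)/N=C(\N)n2nc(C)cc2-c2ccccc2)cc1`, has not yet been measured. It differs from compound 2 in one place: 4-methylphenyl in place of naphthalen-1-yl on a saturated chain carbon bound to a sulfur. Both compound 1 and compound 3 carry a methyl-substituted benzyl group on that sulfur, and compound 1 sits close to compound 2 in this assay, so little movement is foreseen. The step from compound 2 to compound 3 in this assay is expected to be a 1.2-fold lower number from compound 2 to compound 3 (0.08 log units; within the scatter), which is no change beyond the scatter. Compound 3 is therefore estimated at 10000 nM in this assay, with a likely range from 5000 nM to 20000 nM.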

Compound 3, half-maximal inhibitory concentration: 30000 nM
For compound 3 the middle estimate is 3.0-fold (0.48 log units) below the measured one; the whole stated range lies below it.
By their numbers in this assay, from the lowest: compounds 1 and 2 (each within the scatter of the next); then compound 3.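

For the compounds shown here, until now no two measured compounds differed in only one place, so this is the first reading of what a single change on this sulfur-linked carbon does: in this assay, 4-methylphenyl in place of naphthalen-1-yl gives a 2.5-fold higher number from compound 2 to compound 3 (0.40 log units; beyond the scatter), a modest step but one beyond the scatter, so the number here does respond to the group at this position. The change takes the group from two six-membered aromatic rings of carbon to one that carries a methyl group, and a single pair cannot show whether the lost ring, the added methyl or the place of that methyl accounts for the step. Nothing measured here gives a reason for the result.

The compounds shown leave open whether the number would move further with a plain phenyl or with a phenyl ring bearing an amine or a carboxylic acid at this position. They also leave open how a longer chain in place of the single saturated carbon would read, and whether the same swap would give a similar step on a different core.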